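The source may report more compounds than this note shows. Statements on the series, on what has been measured and on what is new or still open speak of the compounds shown alone.

Measured so far:
compound 1 `Cc1ccc(OCC(=O)N(Cc2cccs2)c2cccnc2)cc1` — 198 nM
compound 2 `CCN(Cc1cccs1)C(=O)COc1ccc(F)cc1` — 422 nM
compound 3 `CCN(Cc1cc[nH]n1)C(=O)COc1ccc(C)cc1` — "not active" (no number reported)

In an assay on HEK293 cells for agonist activity at transient receptor potential cation channel subfamily M member 8 (Homo sapiens), read by fluorescence and calcium flux, with a stated time of 15 min (a lower number here means that less compound is needed, a higher number that more compound is needed for the effect), compound 1 gives 198 nM, the lowest of the two numbers recorded here. Compound 2 gives 422 nM, a number higher than that of compound 1 by more than the usual scatter. Compound 3 is reported as "not active" (no number reported), and no number is given for it. The next compound, compound 4 `Cc1ccc(OCC(=O)N(Cc2cccs2)CC(C)C)cc1`, differs from compound 1 in a single place: isobutyl in place of pyridin-3-yl on an amide-type nitrogen. For the measured compounds named here, no step between two measured compounds isolates this change, so the expectation rests on the three values alone. The expected step is a 2.0-fold higher number from compound 1 to compound 4 (0.31 log units; beyond the scatter), a modest move toward a higher number, roughly at the edge of the scatter. Compound 4 is therefore estimated at 400 nM, within a range from 120 nM to 1500 nM.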

Compound 4, half-maximal effective concentration: 900 nM
Estimate against measurement, compound 4: 2.3-fold (0.35 log units) below, within the range that was stated.
By their numbers in this assay, from the lowest: compound 1; then compound 2; then compound 4.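

Isobutyl in place of pyridin-3-yl on an amide-type nitrogen gives a 4.5-fold higher number from compound 1 to compound 4 (0.66 log units; beyond the scatter) in this assay and this is the first single change that can be read among these compounds. It shows that the number at this position moves with the group carried there, with the pyridin-3-yl ring on the lower side and the open isobutyl chain on the higher. Nothing available gives a reason for this step. On these data alone, whether phenyl or cyclohexyl at this nitrogen would stay close to pyridin-3-yl remains open, so the ring cannot yet be separated from its ring nitrogen.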